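From Dichlorophenyl to Difluorophenyl on the Carbonyl Carbon

The source may report more compounds than this note shows. Statements on the series, on what has been measured and on what is new or still open speak of the compounds shown alone.

compound 1 `COc1cc(-c2cc(/C=C/C(=O)c3ccc(N)cc3)[nH]n2)cc(OC)c1OC`: 98%
compound 2 `COc1cc(-c2cc(/C=C/C(=O)c3ccc(Cl)c(Cl)c3)[nH]n2)cc(OC)c1OC`: 93%

In a functional assay on KM12 cells (Homo sapiens) for cytotoxicity, read by sulforhodamine B assay, with a stated time of 48 h, tested at 0.1 uM (on this read-out lower numbers stand for a stronger effect and higher numbers for a weaker effect at the one concentration tested), compound 1 gives 98%. In the same assay compound 2 gives 93%. Among the measured compounds shown here, the single measured step, a number 5 percentage points lower from compound 1 to compound 2 (within the scatter), exchanges the group on the carbonyl carbon, and it stays within the scatter. Compound 2 therefore stands with a number that the measurements cannot separate from that of compound 1; neither compound stands apart on this read-out.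

Compound 3 is `COc1cc(-c2cc(/C=C/C(=O)c3ccc(F)c(F)c3)[nH]n2)cc(OC)c1OC`. It differs from compound 2 in one place: 3,4-difluorophenyl in place of 3,4-dichlorophenyl on a carbonyl carbon. For the measured compounds named here, the only step that bears on this change is a number 5 percentage points lower from compound 1 to compound 2 (within the scatter), a change at the same carbonyl carbon that moved the number by an amount within the scatter. The expectation for compound 3 in this assay is therefore no step beyond the scatter, which means no change at the digits printed from compound 2 to compound 3 (within the scatter) is expected. Compound 3 is estimated at 93%, within 80% to 102%.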

Compound 3, a percentage reported as activity, at one concentration (the size of the read-out at that concentration, not a potency): 92%
Compound 3: middle estimate off by 1 percentage points, on the high side; the measured number falls inside the stated range.
By their numbers in this assay, from the lowest: compounds 3, 2 and 1 (each within the scatter of the next).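

In this assay the exchange of 3,4-dichlorophenyl for 3,4-difluorophenyl on the carbonyl carbon gives a number 1 percentage points lower from compound 2 to compound 3 (within the scatter), so replacing both chlorine atoms with fluorine does not separate the two compounds on this read-out. Set against the 4-aminophenyl group, the 3,4-difluorophenyl group gives a number 6 percentage points lower from compound 1 to compound 3 (within the scatter), which means that three different aryl groups at this position now carry numbers the measurements cannot tell apart, where the earlier pair offered only two. No measurement at hand explains this lack of separation.

Going by these compounds, whether a carboxylic acid, a morpholine or a longer alkyl chain at this carbonyl carbon would move the number beyond the scatter remains open. The compounds shown also leave open whether these three would separate at another concentration.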